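The source may report more compounds than this note shows. Statements on the series, on what has been measured and on what is new or still open speak of the compounds shown alone.

Three compounds share a saturated bicyclic core carrying a sulfone, and all have been examined in an assay on isolated protein for displacement of a labelled ligand from 5-hydroxytryptamine receptor 6 (Homo sapiens); a higher number here means a weaker inhibitor, a lower number a stronger inhibitor. Compound 1, `N#Cc1cccc(S(=O)(=O)c2ccc3c(c2)CCC[C@H]3C=N)c1`, gives 0.501 nM. Compound 2, `NC[C@@H]1CCCc2cc(S(=O)(=O)Cc3ccccc3)ccc21`, gives 158 nM. Compound 3, `O=C1CN=C(NC[C@@H]2CCCc3cc(S(=O)(=O)c4cccc(F)c4)ccc32)N1`, gives 0.1 nM, the lowest of the three numbers; its gap to compound 1 is the smaller one and its gap to compound 2 the larger one, and both lie beyond the scatter of repeated measurements, so compound 3 stands as the strongest of the three in this assay.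

Compound 4, `COC(=O)NC[C@@H]1CCCc2cc(S(=O)(=O)c3cccc(F)c3)ccc21`, is not yet measured. It differs from compound 3 in one place: a group of 4 heavy atoms (2 carbon, 2 oxygen; no ring) in place of a group of 6 heavy atoms (3 carbon, 2 nitrogen, 1 oxygen; one five-membered non-aromatic ring with 2 hetero atoms), on an amine nitrogen. Among the compounds with values here, no pair of measured compounds differing in a single place is available to say what such a change is worth. Within the data shown here, the group that leaves carries a hydrogen-bond donor, while the methoxycarbonyl that enters carries none, and the only other compound here with a small nitrogen group on that chain, compound 2, sits far higher than compound 3, though the two differ elsewhere too. A weakening is therefore expected, of a size beyond the scatter, given as the step of a 100-fold higher number from compound 3 to compound 4 (2.00 log units; beyond the scatter). For compound 4 the expected value in this assay is 10 nM, within a range from 1 nM to 100 nM.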

Compound 4, inhibition constant: 1.59 nM
Compound 4: the middle estimate sits 6.3-fold (0.80 log units) above what was measured; measured number inside the range.
By their numbers in this assay, from the lowest: compound 3; then compound 1; then compound 4; then compound 2.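

In this assay, within the data shown here, replacing the ring-bearing group on the amine nitrogen with methoxycarbonyl gives a 16-fold higher number from compound 3 to compound 4 (1.20 log units; beyond the scatter), the first direct reading of what a change at this place is worth, and it shows that this place clearly affects the result. Even so, compound 4 still gives 1.59 nM with no ring and no hydrogen-bond donor in this group, so neither feature is needed for a value of this order, although the compound with both features has the lower number. Nothing measured here explains the size of this step.

The change removes the ring and the hydrogen-bond donor and shortens the group all at once, so this single pair cannot show how much of the step belongs to each of these differences. The compounds shown also leave open how the same shared core would read with a plain amine, an acetyl group or an ethoxycarbonyl group on that nitrogen, and such compounds would help to separate these contributions.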